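This account rests on a few compounds, and the source may have more. Where it says the series, first, only, none or still open, it means among the compounds named here.

In a physicochemical assay for solubility, read by HPLC, at pH 7.4 (a lower number here means a less soluble compound, a higher number a more soluble compound), compound 1 `CNCc1cc(N)c(Nc2ccc(C#N)cc2)cc1Oc1c(C)cc(C#N)cc1C` gives 159 ug/mL and compound 2 `CC(=O)OCc1cc(N)c(Nc2ccc(C#N)cc2)cc1Oc1c(C)cc(C#N)cc1C` gives 0.2 ug/mL, the lower of the two numbers. Compound 3 `CC(=O)OCc1cc(N)c(Nc2ccc(C#N)cc2)cc1Oc1c(C)cc(CCC#N)cc1C` keeps the acetoxy of compound 2 and differs from it elsewhere: 2-cyanoethyl in place of cyano on an aromatic carbon. Going by the values given here, the only measured step, an 800-fold lower number from compound 1 to compound 2 (2.90 log units; beyond the scatter), is large but concerns acetoxy in place of methylamino on a saturated chain carbon, so it does not bear directly on this change. Among the compounds with values here, no measured step covers this exchange, so no step beyond the scatter is expected in this assay. The estimated step is no change at the digits printed from compound 2 to compound 3 (within the scatter). For compound 3 the expected value is 0.2 ug/mL, with an estimated range of 0.05 ug/mL to 0.8 ug/mL.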

Compound 3, solubility: 1.86 ug/mL
Beside the measured number, compound 3's estimate is 9.3-fold (0.97 log units) below it; measured number above the stated range.
By their numbers in this assay, from the lowest: compound 2; then compound 3; then compound 1.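

In this assay, 2-cyanoethyl in place of cyano on the aromatic carbon meta to two methyl groups gives a 9.3-fold higher number from compound 2 to compound 3 (0.97 log units; beyond the scatter), beyond the scatter. Going by these compounds alone, the earlier compounds varied only the saturated chain carbon, so this is the first sign that this aromatic position also moves the number, if modestly. Nothing measured here explains the rise.

The compounds shown leave open whether a longer chain, an amine or a carboxylic acid at this position would raise the number further, and whether the step would hold with methylamino in place of acetoxy.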